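From compound 3 to compound 4: one side group changes

The source may report more compounds than this note shows. Statements on the series, on what has been measured and on what is new or still open speak of the compounds shown alone.

In an ADME assay on BaF3 cells (Mus musculus) for cytotoxicity, read by CellTiter-Glo and CCK-8 assay, with a stated time of 72 h (on this read-out higher numbers stand for weaker inhibition of growth and lower numbers for stronger inhibition of growth), compound 3 (`CCC(=O)Nc1ccc(C(=O)Nc2ccc(C)c(Nc3nccc(-c4cccnc4)n3)c2)cc1`) gives only a limit (> 10000 nM) and not a number. Compound 1 (`CCC(=O)NCc1ccc(C(=O)Nc2ccc(C)c(Nc3nccc(-c4cccnc4)n3)c2)cc1`) also gives only a limit (> 10000 nM). This is the limit of > 10000 nM in this assay, at which 2 of the 3 values shown sit, and it leaves compound 3 with no exact place on the scale. Compound 2 (`CCC(=O)NCc1cccc(C(=O)Nc2ccc(C)c(Nc3nccc(-c4cccnc4)n3)c2)c1`) is the only one of the three with a true number (4750 nM).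

Compound 4 (`C=CC(=O)Nc1cccc(C(=O)Nc2ccc(C)c(Nc3nccc(-c4cccnc4)n3)c2)c1`) has not been measured yet. The change from its neighbour is 3-((vinylcarbonyl)amino)phenyl in place of 4-(propanoylamino)phenyl on a carbonyl carbon and it means that 3-((vinylcarbonyl)amino)phenyl takes the place of 4-(propanoylamino)phenyl on a carbonyl carbon. Among the measured compounds shown here, the one measured step that touches compound 3 is a step that the two limits leave unreadable from compound 1 to compound 3 and it offers no size to carry over. For the measured compounds named here, the only readable guide is therefore compound 2 at 4750 nM in this assay, so a value of similar order is expected for the new compound. The expected step is an at least 2.5-fold lower number from compound 3 to compound 4 (0.39 log units; beyond the scatter) toward stronger inhibition of growth, and its size is only loosely known. Another limit remains possible. For compound 4 the estimated value is 4000 nM (expected range 1000 nM to 10000 nM).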

Compound 4, concentration for 50% growth inhibition: 2480 nM
Compound 4: the middle estimate sits 1.6-fold (0.21 log units) above what was measured; the range from low to high includes it.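

In this assay, putting 3-((vinylcarbonyl)amino)phenyl in place of 4-(propanoylamino)phenyl on a carbonyl carbon gives an at least 4.0-fold lower number from compound 3 to compound 4 (0.60 log units; beyond the scatter), the first step involving compound 3 that can be read at all, so this swap does change growth inhibition. That size is only a lower bound on the step because the value of compound 3 is a limit and not a number: the limit of > 10000 nM in this assay, at which 2 of the 4 values shown sit. The other step, with (vinylcarbonyl)amino in place of (propanoylamino)methyl on an aromatic carbon, is a 1.9-fold lower number from compound 2 to compound 4 (0.28 log units; within the scatter), so this assay cannot tell these two compounds apart, and the extra double bond in the new group brings no readable gain over compound 2.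

The step to compound 4 changes both where the side group sits on the ring and which chain it carries, so the compounds shown cannot say which of the two matters; a 3-(propanoylamino)phenyl group would separate them. As far as these compounds go, it also remains open how a plain amine or a longer chain in place of the vinylcarbonyl group would read in this assay.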